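From compound 2 to compound 3: a seven-membered ring

This account rests on a few compounds, and the source may have more. Where it says the series, first, only, none or still open, it means among the compounds named here.

Compound 1 `CN1CC[C@@H](N(c2cc(C#CC(C)(C)C)sc2C(=O)O)C(=O)[C@H]2CC[C@H](C)CC2)C1=O` with 64 h
Compound 2 `CN1CC[C@H](N(c2cc(C#CC(C)(C)C)sc2C(=O)O)C(=O)[C@H]2CC[C@H](C)CC2)C1=O` with 4.66 h

In an ADME assay on the whole organism (Rattus norvegicus, strain Sprague-Dawley) for metabolic stability, read by LC-MS, with a stated time of 72 h, at a dose of 3 mg/kg by the oral route (on this read-out higher numbers stand for a longer-lived compound and lower numbers for a shorter-lived compound), compound 2 holds the lower of the two numbers, at 4.66 h. Compound 3 `CN1CCCC[C@@H](N(c2cc(C#CC(C)(C)C)sc2C(=O)O)C(=O)[C@H]2CC[C@H](C)CC2)C1=O` has not yet been measured. It departs from compound 2 in one place: 1-methyl-2-oxoazepan-3-yl in place of 1-methyl-2-oxopyrrolidin-3-yl on an amide-type nitrogen. This puts 1-methyl-2-oxoazepan-3-yl in place of 1-methyl-2-oxopyrrolidin-3-yl on an amide-type nitrogen. Among the measured compounds shown here, only one measured step is available, a 14-fold lower number from compound 1 to compound 2 (1.14 log units; beyond the scatter), and it is large. It goes with the fact that compounds 1 and 2 differ only in the configuration as drawn, so it shows how far this read-out can move but does not test a change of ring size. For the measured compounds named here, with no measured step of that kind, only a modest rise is expected. The estimated step is a 1.7-fold higher number from compound 2 to compound 3 (0.23 log units; within the scatter). For compound 3 the estimate is 8 h, with an expected range from 2.5 h to 30 h.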

Compound 3, half-life: 4.31 h
Compound 3: the middle estimate sits 1.9-fold (0.27 log units) above what was measured; measured number inside the range.
By their numbers in this assay, from the lowest: compounds 3 and 2 (each within the scatter of the next); then compound 1.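

Setting 1-methyl-2-oxoazepan-3-yl in place of 1-methyl-2-oxopyrrolidin-3-yl on an amide-type nitrogen gives a 1.1-fold lower number from compound 2 to compound 3 (0.03 log units; within the scatter) in this assay, so going from the five-membered to the seven-membered ring leaves the two compounds level. The larger ring does not close the earlier gap either, as the comparison with the top number shows a 15-fold lower number from compound 1 to compound 3 (1.17 log units; beyond the scatter). At this position, the one large movement among the pairs differing in a single respect therefore goes with configuration and not with ring size, the earlier step being tied to this: the fact that compounds 1 and 2 differ only in the configuration as drawn

The compounds shown leave open whether the seven-membered ring in the other drawn configuration would come near compound 1 at 64 h. They also leave open how 1-methyl-2-oxopiperidin-3-yl, with its six-membered ring, or an open-chain amide would read at this place.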